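The source may report more compounds than this note shows. Statements on the series, on what has been measured and on what is new or still open speak of the compounds shown alone.

The measured compounds, in order:

compound 1, `CCCCc1ccc(CN(Cc2ccccc2)S(=O)(=O)c2ccc(C)cc2)c(=O)n1Cc1ccc(-c2ccccc2-c2nn[nH]n2)cc1`, 60 nM
compound 2, `CCCCc1ccc(CN(C)S(=O)(=O)c2ccc(C)cc2)c(=O)n1Cc1ccc(-c2ccccc2-c2nn[nH]n2)cc1`, 8 nM
compound 3, `CCCCc1ccc(CN(Cc2ccccc2)S(=O)(=O)c2ccccc2)c(=O)n1Cc1ccc(-c2ccccc2-c2nn[nH]n2)cc1`, 20 nM

All three share one core and were tested in a functional assay (aorta) for antagonist activity, with Oryctolagus cuniculus as the target; a lower number here means a stronger inhibitor, a higher number a weaker inhibitor. In this assay compound 2 gives 8 nM, compound 3 gives 20 nM, and compound 1 gives 60 nM.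

Compound 1 and compound 2 differ in one place only: hydrogen in place of phenyl on a saturated chain carbon bound to a sulfonamide nitrogen. That single change made a step of a 7.5-fold lower number from compound 1 to compound 2 (0.88 log units; beyond the scatter). Compound 1 and compound 3 also differ in one place: hydrogen in place of methyl on an aromatic carbon, with a step of a 3.0-fold lower number from compound 1 to compound 3 (0.48 log units; beyond the scatter). So the core of compound 3 is the core of compound 1 without that methyl, and the two cores differ in nothing else.

Compound 4, `CCCCc1ccc(CN(C)S(=O)(=O)c2ccccc2)c(=O)n1Cc1ccc(-c2ccccc2-c2nn[nH]n2)cc1`, has not yet been measured. It stands to compound 3 exactly as compound 2 stands to compound 1: hydrogen in place of phenyl on a saturated chain carbon bound to a sulfonamide nitrogen. The place is described in the same words for both pairs, so this is the same change made on the other core. Among the four compounds it occurs twice.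

The step from compound 3 to compound 4 is expected to be of the same kind and a similar size, estimated at a 5.0-fold lower number from compound 3 to compound 4 (0.70 log units; beyond the scatter), beside the measured 7.5-fold lower number from compound 1 to compound 2 (0.88 log units; beyond the scatter). This expectation rests on compound 1 and compound 2 alone, one pair, so the size of the expected step is uncertain. Compound 4 is therefore estimated to give 4 nM, expected to lie between 1.5 nM and 12 nM.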

Compound 4, half-maximal inhibitory concentration: 2 nM
For compound 4 the middle estimate is 2.0-fold (0.30 log units) above the measured one; the measured number falls inside the stated range.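

The change from benzyl to methyl on the core of compound 3 gives, in this assay, a 10-fold lower number from compound 3 to compound 4 (1.00 log units; beyond the scatter), and this step matches the one seen on the other core: the same change on two cores in this assay, a 7.5-fold lower number (0.88 log units; beyond the scatter) from compound 1 to compound 2 and a 10-fold lower number (1.00 log units; beyond the scatter) from compound 3 to compound 4, 1.3-fold (0.12 log units) apart, within the scatter of two such steps

Removing the methyl on an aromatic carbon also carries over, with a 4.0-fold lower number from compound 2 to compound 4 (0.60 log units; beyond the scatter) on the core that already has the smaller group, and it too matches its earlier step: the same change on two cores in this assay, a 3.0-fold lower number (0.48 log units; beyond the scatter) from compound 1 to compound 3 and a 4.0-fold lower number (0.60 log units; beyond the scatter) from compound 2 to compound 4, 1.3-fold (0.12 log units) apart, within the scatter of two such steps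

Across these four compounds, then, each change had a similar size on both cores, so the two changes appear to add up independently here, but this rests on one pair of steps for each change in a single assay and shows neither why the numbers fall nor whether the same holds on any other core in the series.

Going by these compounds alone, it remains open how the number would respond to an ethyl or a longer chain in place of the benzyl, which would show whether methyl is the best choice or simply the only small group seen here. As far as these compounds go, it is also open whether a chlorine or a methoxy group in place of the methyl on an aromatic carbon would follow the same pattern.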